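Amide-side variation on a shared core: working notes

The source may hold more compounds than are shown below. What is called first, only, known or untested is meant among the compounds shown, and "the series" means these compounds.

Measured in an ADME assay on L02 cells (Homo sapiens) for antiproliferative activity, read by MTT assay, with a stated time of 48 h; on this read-out higher numbers stand for weaker inhibition and lower numbers for stronger inhibition:
compound 1, `CCn1c(C(=O)NCCCN(C)C)ccc1C(CC)(CC)c1ccc(OCCC(O)(CC)CC)c(C)c1`: 2420 nM
compound 2, `CCn1c(C(=O)NCCN)ccc1C(CC)(CC)c1ccc(OCCC(O)(CC)CC)c(C)c1`: 2940 nM
compound 3, `CCn1c(C(=O)N(C)CC(=O)O)ccc1C(CC)(CC)c1ccc(OCCC(O)(CC)CC)c(C)c1`: 2150 nM

Compound 1 stands second highest of the three numbers; its nearest neighbour is compound 3 with a 1.1-fold lower number from compound 1 to compound 3 (0.05 log units; within the scatter) and its furthest is compound 2 with a 1.2-fold higher number from compound 1 to compound 2 (0.08 log units; within the scatter). The step of a 1.4-fold lower number from compound 2 to compound 3 (0.14 log units; within the scatter) also lies within the scatter, so the three variants on this core have so far given no number separable from the others in this assay.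

Compound 4, `CCC(C)C(CO)NC(=O)c1ccc(C(CC)(CC)c2ccc(OCCC(O)(CC)CC)c(C)c2)n1CC`, is not yet measured. It differs from compound 1 as follows: 1-(hydroxymethyl)-2-methylbutyl in place of 3-(dimethylamino)propyl on an amide-type nitrogen. The measured steps of a 1.2-fold higher number from compound 1 to compound 2 (0.08 log units; within the scatter) and a 1.1-fold lower number from compound 1 to compound 3 (0.05 log units; within the scatter) also changed the group on the carbonyl carbon and stayed within the scatter; none of them introduced a 1-(hydroxymethyl)-2-methylbutyl group, so their bearing is indirect. On these grounds compound 4 is expected to give about 2500 nM in this assay, a step of a 1.0-fold higher number from compound 1 to compound 4 (0.01 log units; within the scatter), with no movement beyond the scatter expected. The expected range for compound 4 is 1200 nM to 5200 nM.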

Compound 4, half-maximal inhibitory concentration: > 50000 nM
Compound 4 gave a limit, no number (the forecaster's own chance of this, stated with the estimate: 0%); middle value at least 20-fold (1.30 log units) from the limit.
By their numbers in this assay, from the lowest: compounds 3, 1 and 2 (each within the scatter of the next). At a limit, above all of these: compound 4.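

Against all three earlier groups on the amide-type nitrogen, 1-(hydroxymethyl)-2-methylbutyl gives steps beyond the scatter (an at least 20-fold higher number from compound 1 to compound 4 (1.31 log units; beyond the scatter); an at least 23-fold higher number from compound 3 to compound 4 (1.36 log units; beyond the scatter); an at least 17-fold higher number from compound 2 to compound 4 (1.23 log units; beyond the scatter)). Among the compounds shown here, this position therefore responds strongly to at least one change, though the earlier compounds alone gave no separable number. Compound 3 has no amine in its side group, yet a 1.1-fold lower number from compound 1 to compound 3 (0.05 log units; within the scatter) stays within the scatter, so the absence of an amine does not by itself set compound 4 apart in this assay. For compound 4, the value is a limit and not a number: the limit of > 50000 nM in this assay, at which 1 of the 4 values shown sits.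

The compounds shown leave open whether the hydroxymethyl group or the branched 2-methylbutyl chain carries the step. An unbranched hydroxyalkyl chain and a 2-methylbutyl group without the hydroxyl would separate these two parts.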